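This account rests on a few compounds, and the source may have more. Where it says the series, first, only, none or still open, it means among the compounds named here.

Of the compounds shown here, three built on one shared core have been tested in a physicochemical assay for metabolic stability, read by LC-MS, in phosphate buffer, with a stated time of 3 h, at pH 7.4, tested at 50 uM; a higher number here means that more of the compound is left, a lower number that less of the compound is left. Compound 1, with the structure `CCOC(=O)C1=C(S[C@@H]2CN[C@H](C(=O)Nc3cccc(C(=O)OCC)c3)C2)[C@H](C)[C@@H]2[C@@H]([C@@H](C)OC(=O)[C@@H](N)C(C)C)C(=O)N12`, gives > 95%, which is a limit of the assay rather than a number. Compound 2, with the structure `C[C@@H](O)[C@H]1C(=O)N2C(C(=O)OCC(F)(F)F)=C(S[C@@H]3CN[C@H](C(=O)Nc4cccc(C(=O)O)c4)C3)[C@H](C)[C@H]12`, also reaches a limit of the assay, > 95%. Compound 3, with the structure `C[C@@H](O)[C@H]1C(=O)N2C3=C(S[C@@H]4CN[C@@H](C4)C(=O)Nc4cccc(c4)C(=O)OCCCCOC3=O)[C@H](C)[C@H]12`, gives > 95%, once more a limit. Among the measured compounds shown here, compound 2 therefore stands where every measured value stands, and no compound can be placed above or below another on these numbers. Compound 4, with the structure `C[C@@H](O)[C@H]1C(=O)N2C(C(=O)OCOC(=O)OC(C)(C)C)=C(S[C@@H]3CN[C@H](C(=O)Nc4cccc(C(=O)O)c4)C3)[C@H](C)[C@H]12`, has not yet been measured. It differs from compound 2 in one place: (tert-butoxycarbonyl)oxy in place of trifluoromethyl on a saturated chain carbon bound to an oxygen next to a carbonyl group. For the measured compounds named here, no pair of measured compounds differs by a change of this kind, so the size of the step rests on expectation alone. Because all three values sit at the limit of > 95% in this assay, at which 3 of the 3 values shown sit, the step of a number at least 3 percentage points lower from compound 2 to compound 4 (that floor lies within the scatter) is expected to be small, with compound 4 expected to land near the limit or just under it. In this assay compound 4 is estimated at 92%, within a range from 78% to 97%.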

Compound 4, percent of the compound remaining: > 95%
Compound 4: a limit, no number; the forecaster's own chance of this, stated with the estimate: 55%; at least 3 percentage points between middle value and limit.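

Compound 2 and compound 4 both sit at a limit in this assay, so the step between them cannot be read: the limit of > 95% in this assay, at which 4 of the 4 values shown sit. The compounds shown leave open whether trifluoromethyl and (tert-butoxycarbonyl)oxy differ at all in the percent of compound remaining.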